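The source may report more compounds than this note shows. Statements on the series, on what has been measured and on what is new or still open speak of the compounds shown alone.

Measured so far:
Compound 1 `O=c1nc(-c2ccccc2)c2cc(-c3cccc(F)c3)ccc2[nH]1` gives in an ADME assay on THP-1 cells (Homo sapiens) for cytotoxicity, read by MTT assay, with a stated time of 72 h (on this read-out lower numbers stand for an effect already at smaller amounts and higher numbers for an effect only at larger amounts of compound), only the limit > 50000 nM.
Compound 2 `CNC(=O)c1cccc(-c2ccc3[nH]c(=O)nc(-c4ccccc4)c3c2)c1` gives in this assay only the limit > 50000 nM.

Compound 1 thus stands at the limit of > 50000 nM in this assay, at which 2 of the 2 values shown sit, without a number of its own. Among the compounds with values here, the single measured step, a step that the two limits leave unreadable from compound 1 to compound 2, cannot be read, since both of its ends are limits. Compound 3 `CN1CCN(c2ccc3[nH]c(=O)nc(-c4ccccc4)c3c2)CC1` differs from compound 1 by 4-methylpiperazin-1-yl in place of 3-fluorophenyl on an aromatic carbon. Within the data shown here, no measured step bears on this change; the only available comparison stays between two limits. Compound 3 is therefore expected to remain near the limit too, with a step of a number no higher from compound 1 to compound 3 (the limit leaves the size open) that is expected to stay within the scatter. The estimate for compound 3 is 50000 nM, expected to range from 20000 nM to 100000 nM.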

Compound 3, half-maximal effective concentration: > 50000 nM
Compound 3: a limit, no number; the forecaster's own chance of this, stated with the estimate: 75%; the middle value lies on the limit itself.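

No step can be read from compound 1 to compound 3, since both values are limits and not numbers: the limit of > 50000 nM in this assay, at which 3 of the 3 values shown sit.
The compounds shown leave open at what amount, if any, each takes effect in this assay and whether either replacement alters that amount.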